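Methoxy to chloro on the sulfonyl aryl ring

A few compounds are considered here, and "the series" means these few. Any claim that something is new, unique, unknown or untested is made for them only; others in the source may bear on it.

Compound 3 (`COc1ccc(S(=O)(=O)n2c(-c3cn(-c4ccccc4)nc3-c3ccc(C(F)(F)F)cc3)nc3ccccc32)cc1`) gives 420 nM in a functional assay on MCF7 cells (Homo sapiens) for antiproliferative activity, read by MTT assay, with a stated time of 24 h (a higher number here means a weaker inhibitor, a lower number a stronger inhibitor), and sits within the scatter of compound 2 (`COc1ccc(S(=O)(=O)n2c(-c3cn(-c4ccccc4)nc3-c3ccc(F)cc3)nc3ccccc32)cc1`) with 530 nM and of compound 1 (`Cc1ccc(-c2nn(-c3ccccc3)cc2-c2nc3ccccc3n2S(=O)(=O)c2ccccc2)cc1`) with 830 nM as well. Compound 4 (`O=S(=O)(c1ccc(Cl)cc1)n1c(-c2cn(-c3ccccc3)nc2-c2ccc(C(F)(F)F)cc2)nc2ccccc21`) has chloro in place of methoxy on an aromatic carbon, para to a large group (chloro in place of methoxy on an aromatic carbon) and so reads as 4-methoxyphenyl to 4-chlorophenyl. For the measured compounds named here, no measured step covers this change. Going by the values given here, the one step available, a 1.3-fold lower number from compound 2 to compound 3 (0.10 log units; within the scatter) on another aromatic carbon, is trifluoromethyl in place of fluoro and stays within the scatter. The step expected in this assay goes no further than the scatter, estimated as a 1.1-fold higher number from compound 3 to compound 4 (0.03 log units; within the scatter) in size. The estimate for compound 4 is 450 nM (expected range 200 nM to 1000 nM).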

Compound 4, half-maximal inhibitory concentration: 4320 nM
For compound 4 the middle estimate is 9.6-fold (0.98 log units) below the measured one, and the stated range ends below it.
By their numbers in this assay, from the lowest: compounds 3, 2 and 1 (each within the scatter of the next); then compound 4.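

In this assay the position on the sulfonyl aryl ring, on an aromatic carbon para to a large group, responds strongly: the exchange of methoxy for chloro gives a 10-fold higher number from compound 3 to compound 4 (1.01 log units; beyond the scatter) and is the only step shown that lies beyond the scatter. The earlier change elsewhere on the molecule, a 1.3-fold lower number from compound 2 to compound 3 (0.10 log units; within the scatter) stayed within it. No measurement at hand explains the difference between the two groups.

Open, going by these compounds, is whether an amine or a nitrile at this position keeps the level of compound 3. Also open, on these data alone, is whether the methoxy to chloro change costs as much with fluoro in place of trifluoromethyl.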